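A few compounds are considered here, and "the series" means these few. Any claim that something is new, unique, unknown or untested is made for them only; others in the source may bear on it.

Compound 1, `Cc1ccccc1NC(=S)OCCc1ccccn1`: > 100000 nM
Compound 2, `Cc1cccc(NC(=S)OCCc2ccccn2)c1`: > 100000 nM

Compound 1 and compound 2 are close relatives built on the same core. In an ADME assay on MT4 cells (Homo sapiens) for cytotoxicity, read by MTT assay (on this read-out lower numbers stand for higher toxicity in this test and higher numbers for lower toxicity in this test), compound 1 gives > 100000 nM, which is a limit of the assay rather than a number. In this assay compound 2 gives > 100000 nM, again a limit of the assay rather than a measured number. Compound 2 thus stands at the limit of > 100000 nM in this assay, at which 2 of the 2 values shown sit, so nothing in the data shown separates the two compounds. Compound 3, `S=C(Nc1cccc(Cl)c1)OCCc1ccccn1`, has yet to be measured in this assay. It differs from compound 2 by chloro in place of methyl on an aromatic carbon. For the measured compounds named here, no pair of measured compounds shows what such a change does here, so the expectation rests on compound 2 alone: the values shown sit at the limit, and the expected step of a number no higher from compound 2 to compound 3 (the limit leaves the size open) is none beyond the scatter. Compound 3 is therefore estimated at 100000 nM, with a range from 30000 nM to 300000 nM, most likely reported again only as a limit.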

Compound 3, half-maximal cytotoxic concentration: 47000 nM
The estimate for compound 3 lay 2.1-fold (0.33 log units) above the measured number, within the range that was stated.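

Chloro in place of methyl on this aromatic carbon gives an at least 2.1-fold lower number from compound 2 to compound 3 (0.32 log units; beyond the scatter) in this assay, and so yields a measured number where the earlier compounds gave only limits. This position is therefore not silent in this test: swapping one heavy atom, with no change in the count of hydrogen-bond donors or acceptors and no net charge, is enough to shift the read-out toward higher toxicity in this test. On these data alone, the full size of the step stays unknown because only one of its two ends is a number: the limit of > 100000 nM in this assay, at which 2 of the 3 values shown sit.

As far as these compounds go, it remains open whether another group on the same carbon, such as an amine or a methoxy group, would also lower the number. Also open, from the compounds shown here alone, is whether chloro would do the same in the place held by the methyl of compound 1.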